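Swapping 4-hydroxyphenyl for anilino on a shared core

This account rests on a few compounds, and the source may have more. Where it says the series, first, only, none or still open, it means among the compounds named here.

Measured in a functional assay, read by spectrophotometry, with a stated time of 3 min; on this read-out lower numbers stand for stronger inhibition and higher numbers for weaker inhibition
- Compound 1 `Cc1ccc2[nH]c(=O)c(/C=N/c3ccc(O)cc3)cc2c1` gives 5240 nM
- Compound 2 `O=c1[nH]c2ccccc2cc1/C=N/c1ccc(O)cc1` gives 7150 nM
- Compound 3 `Cc1ccc2[nH]c(=O)c(/C=N/c3ccc(S(N)(=O)=O)cc3)cc2c1` gives 1200000 nM

Compound 1 stands at the low end of these numbers, but it does not stand there alone. Putting hydrogen in place of methyl on an aromatic carbon gives a 1.4-fold higher number from compound 1 to compound 2 (0.13 log units; within the scatter). Putting sulfamoyl in place of hydroxy on an aromatic carbon gives a 230-fold higher number from compound 1 to compound 3 (2.36 log units; beyond the scatter).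

The next compound is compound 4 `Cc1ccc2[nH]c(=O)c(/C=N/Nc3ccccc3)cc2c1`, which keeps the core of compound 1. Here anilino takes the place of 4-hydroxyphenyl on a double-bonded nitrogen: anilino in place of 4-hydroxyphenyl on a double-bonded nitrogen. For the measured compounds named here, no measured step makes this exact change. The methyl step says little about it, since it touches another part of the molecule. The sulfamoyl step is the closer guide, as compound 4 also loses the hydroxy, and a 230-fold higher number from compound 1 to compound 3 (2.36 log units; beyond the scatter) shows that a change there can matter greatly. However, sulfamoyl does not enter compound 4, so a much smaller rise seems likely, and the direction is uncertain. The expected change is a 2.3-fold higher number from compound 1 to compound 4 (0.36 log units; beyond the scatter). For compound 4 the estimated value is 12000 nM, with an expected range of 2500 nM to 80000 nM.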

Compound 4, half-maximal inhibitory concentration: 8470 nM
Compound 4: the middle estimate sits 1.4-fold (0.15 log units) above what was measured; measured number inside the range.
By their numbers in this assay, from the lowest: compounds 1, 2 and 4 (each within the scatter of the next); then compound 3.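

In this assay, anilino in place of 4-hydroxyphenyl on a double-bonded nitrogen gives a 1.6-fold higher number from compound 1 to compound 4 (0.21 log units; within the scatter), so this swap leaves the number within the usual scatter, even though the two groups differ in the atom that joins or carries the polar part: the oxygen of the hydroxy leaves and a nitrogen enters. Set against the large 230-fold higher number from compound 1 to compound 3 (2.36 log units; beyond the scatter), this shows that losing the hydroxy does not by itself produce a large rise, since compound 4 has no hydroxy and still stays within the scatter of compound 1; the large rise is seen only with sulfamoyl, and the two groups exchanged here match in size, ring, hydrogen-bond donors and acceptors, and charge as counted from their structures. Nothing measured on these groups says why this swap leaves the number within the scatter.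

The compounds shown leave open whether a methoxy group or a carboxylic acid on the anilino ring would move the number, and whether a hydroxy on that ring would do so. They also leave open what hydrogen in place of methyl on the shared core does when anilino is present.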